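A few compounds are considered here, and "the series" means these few. Any claim that something is new, unique, unknown or untested is made for them only; others in the source may bear on it.

Working notes on the series, read in a functional assay on KBVIN cells (Homo sapiens) for antiproliferative activity, read by sulforhodamine B assay, with a stated time of 3 days; on this read-out lower numbers stand for an effect already at smaller amounts and higher numbers for an effect only at larger amounts of compound. Compound 1 (`CCC1=C(O)c2c(oc(-c3ccc(C(C)C)cc3)cc2=O)C(CC)(CC)C1=O`) gives 1.08 uM, compound 2 (`CCC1=C(O)c2c(oc(-c3ccc(O)cc3)cc2=O)C(CC)(CC)C1=O`) gives 20.6 uM, and compound 3 (`CCC1=C(O)c2c(oc(-c3ccc(OC)cc3)cc2=O)C(CC)(CC)C1=O`) gives 0.68 uM. Compound 3 sits level with compound 1, with isopropyl replaced by methoxy: a 1.6-fold lower number from compound 1 to compound 3 (0.20 log units; within the scatter). It stands far from compound 2, with methyl in place of hydrogen on the oxygen: a 30-fold lower number from compound 2 to compound 3 (1.48 log units; beyond the scatter).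

Next is compound 4 (`CCOc1ccc(-c2cc(=O)c3c(o2)C(CC)(CC)C(=O)C(CC)=C3O)cc1`), where methoxy becomes ethoxy: methyl in place of hydrogen on a saturated chain carbon bound to an oxygen on an aromatic ring. Methyl enters on a saturated chain carbon bound to an oxygen on an aromatic ring. The large step of a 30-fold lower number from compound 2 to compound 3 (1.48 log units; beyond the scatter) concerns the hydrogen on that oxygen, and neither compound 3 nor compound 4 carries one there, so it says little about this change. The closer guide is the step of a 1.6-fold lower number from compound 1 to compound 3 (0.20 log units; within the scatter), which stayed small. No step beyond the scatter is therefore expected in this assay, and the expected step is a 1.2-fold higher number from compound 3 to compound 4 (0.07 log units; within the scatter). Compound 4 is estimated at 0.8 uM, with an expected range of 0.35 uM to 1.8 uM.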

Compound 4, concentration for half-maximal effect: 7.54 uM
For compound 4 the middle estimate is 9.4-fold (0.97 log units) below the measured one; measured number outside the range, above it.
By their numbers in this assay, from the lowest: compounds 3 and 1 (each within the scatter of the next); then compound 4; then compound 2.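

In this assay, the substituent on the oxygen proves sensitive to a very small change: one added methyl on the saturated chain carbon gives an 11-fold higher number from compound 3 to compound 4 (1.04 log units; beyond the scatter), so methoxy and ethoxy are not interchangeable here, although methoxy and isopropyl read within the scatter of each other. Ethoxy also separates from isopropyl, with a 7.0-fold higher number from compound 1 to compound 4 (0.84 log units; beyond the scatter), and capping the hydroxy oxygen with ethyl gives only a 2.7-fold lower number from compound 2 to compound 4 (0.44 log units; beyond the scatter), so alkylation of that oxygen alone does not bring the number to the level of compound 3. Nothing measured on these compounds accounts for this rise.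

The compounds shown leave open whether a longer chain on that oxygen, such as propoxy, raises the number further or reverses the rise. They also leave open how an amine or a fluorine in place of the ethoxy would read.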